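The source may hold more compounds than are shown below. What is called first, only, known or untested is meant among the compounds shown, and "the series" means these compounds.

Measured in an assay on CHO cells for displacement of a labelled ligand from prostaglandin D2 receptor 2 (Homo sapiens), read by scintillation counting; on this read-out lower numbers stand for stronger inhibition and higher numbers for weaker inhibition: compound 1 `CCCS(=O)(=O)c1cccc(C#Cc2cc(Cl)ccc2OCC(=O)O)c1` gives 9 nM; compound 2 `COCCN(C)S(=O)(=O)c1ccc(C)c(C#Cc2cc(Cl)ccc2OCC(=O)O)c1` gives 4.1 nM; compound 3 `Cc1ccc(S(=O)(=O)Cc2ccccc2)cc1C#Cc1cc(Cl)ccc1OCC(=O)O` gives 5 nM.

In this assay compound 3 sits within the scatter of both of its neighbours: compound 2 gives 4.1 nM and compound 1 gives 9 nM, so the three numbers cannot be ordered. Compound 4 `Cc1ccc(S(=O)(=O)N2CCN(C)CC2)cc1C#Cc1cc(Cl)ccc1OCC(=O)O` is made from compound 3 by the change (4-methylpiperazin-1-yl in place of benzyl on a sulfonyl sulfur). Within the data shown here, the one measured step that bears on it is the other exchange of a group on the same sulfonyl sulfur, a 1.2-fold higher number from compound 2 to compound 3 (0.09 log units; within the scatter), which stayed within the scatter. The step for compound 4 is therefore expected to be small, with no direction beyond the scatter, about a 1.2-fold higher number from compound 3 to compound 4 (0.08 log units; within the scatter). Compound 4 is estimated at 6 nM, expected between 2 nM and 20 nM.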

Compound 4, inhibition constant: 21 nM
The estimate for compound 4 lay 3.5-fold (0.54 log units) below the measured number, outside the stated range (above it).
By their numbers in this assay, from the lowest: compounds 2, 3 and 1 (each within the scatter of the next, the first and the last beyond it); then compound 4.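

In this assay the group on the sulfonyl sulfur proves able to shift the number: 4-methylpiperazin-1-yl in place of benzyl gives a 4.2-fold higher number from compound 3 to compound 4 (0.62 log units; beyond the scatter) and in place of (2-methoxyethyl)(methyl)amino gives a 5.1-fold higher number from compound 2 to compound 4 (0.71 log units; beyond the scatter) while the earlier exchange at this place stayed within the scatter. Benzyl and 4-methylpiperazin-1-yl have the same heavy-atom count, so that count alone does not set the step. Nothing available here explains the step. Going by these compounds, it remains open whether the methyl-bearing ring nitrogen or the ring as a whole matters; morpholin-4-yl or piperidin-1-yl on the same sulfur would separate the two.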